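The source may hold more compounds than are shown below. What is called first, only, known or untested is meant among the compounds shown, and "the series" means these compounds.

Compound 1 `CC(C)c1ccc(-c2nc(SCc3cn(CC(=O)NC(=O)Nc4ccccn4)nn3)nc(Nc3ccc(F)cc3)c2C#N)cc1`: in a functional assay on MCF7 cells (Homo sapiens) for inhibition, read by MTT assay, with a stated time of 72 h (a higher number here means a weaker inhibitor, a lower number a stronger inhibitor), compound 1 gives > 64000 nM, a limit of the assay rather than a number.
Compound 2 `CC(C)c1ccc(-c2nc(SCc3cn(CC(=O)NC(=O)Nc4ccccn4)nn3)nc(Nc3ccc(Cl)cc3)c2C#N)cc1`: in this assay compound 2 gives > 64000 nM, likewise a limit.
Compound 3 `CC(C)c1ccc(-c2nc(SCc3cn(CC(=O)NC(=O)Nc4ccccn4)nn3)nc(Nc3ccccc3F)c2C#N)cc1`: in this assay compound 3 gives > 64000 nM, again a limit.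

Compound 3 therefore stands only at a limit, and the same holds for the other two, all three sitting at the limit of > 64000 nM in this assay, at which 3 of the 3 values shown sit. The steps a step that the two limits leave unreadable from compound 1 to compound 2 and a step that the two limits leave unreadable from compound 1 to compound 3 and a step that the two limits leave unreadable from compound 2 to compound 3 cannot be read, since each joins two limits.

Compound 4 `Cc1ccccc1Nc1nc(SCc2cn(CC(=O)NC(=O)Nc3ccccn3)nn2)nc(-c2ccc(C(C)C)cc2)c1C#N` is the next one to be measured. It differs from compound 3 by methyl in place of fluoro on an aromatic carbon. The three measured steps bear on this change only in that none of them produced a readable value. Nothing in the series suggests that this small exchange moves compound 4 off the limit, so the expected step is a step that the limit leaves unreadable from compound 3 to compound 4, that is none beyond the scatter. For compound 4 the estimate in this assay is 120000 nM, within 50000 nM to 400000 nM, most probably reported again as a limit.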

Compound 4, half-maximal inhibitory concentration: > 64000 nM
Compound 4: no number, only a limit; the forecaster's own chance of this, stated with the estimate: 85%; the middle value is on the limit's open side.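

Compound 4, like compound 1, compound 2 and compound 3, yields no readable step, since each comparison joins two limits: the limit of > 64000 nM in this assay, at which 4 of the 4 values shown sit.

The compounds shown leave open how strongly any of them inhibits in this assay, and whether any change to the aniline-type substituent matters there.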